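A Heavier Halogen on the Phenylamino Group

A few compounds are considered here, and "the series" means these few. Any claim that something is new, unique, unknown or untested is made for them only; others in the source may bear on it.

Compound 1 `Cc1n[nH]c2ccc(-c3nc4cnc(N5CCN(C)CC5)cn4c3Nc3ccc(F)cc3)cc12` is one of three compounds with a shared core read in a functional assay on MV4-11 cells (Homo sapiens) for inhibition, with a stated time of 120 h, tested at 10 uM (on this read-out higher numbers stand for more inhibition at the one concentration tested (going by the name of the read-out) and lower numbers for less inhibition), where compound 1 gives 0%. Compound 3 `Cc1n[nH]c2ccc(-c3nc4cnc(N5CCN(C)CC5)cn4c3Nc3ccccc3)cc12` gives 0%, and compound 2 `Cc1n[nH]c2ccc(-c3nc4cnc(N5CCN(C)CC5)cn4c3Nc3ccc(Br)cc3)cc12` gives 83%. Compound 1 thus stands level with compound 3, the two together at the bottom, while compound 2 sits far above them (a number 83 percentage points higher from compound 1 to compound 2 (beyond the scatter)). Compound 4 `Cc1n[nH]c2ccc(-c3nc4cnc(N5CCN(C)CC5)cn4c3Nc3ccc(Cl)cc3F)cc12` differs from compound 1 by 4-chloro-2-fluorophenyl in place of 4-fluorophenyl on a nitrogen on an aromatic ring. Of the measured steps, a number 83 percentage points higher from compound 1 to compound 2 (beyond the scatter) bears most directly on this change, echoed by a number 83 percentage points lower from compound 2 to compound 3 (beyond the scatter), whereas no change at the digits printed from compound 1 to compound 3 (within the scatter) shows the fluoro itself adding nothing. A substantial rise is therefore expected for compound 4, estimated as a number 50 percentage points higher from compound 1 to compound 4 (beyond the scatter). Compound 4 is expected to give 50%, within 10% to 85%.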

Compound 4, a percentage reported as inhibition, at one concentration (the size of the read-out at that concentration, not a potency): 0%
Estimate against measurement, compound 4: 50 percentage points above, outside the stated range (below it).
By their numbers in this assay, from the lowest: compounds 1, 3 and 4 (each within the scatter of the next); then compound 2.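

In this assay, the change to (4-chloro-2-fluorophenyl)amino brings no gain over (4-fluorophenyl)amino (no change at the digits printed from compound 1 to compound 4 (within the scatter)) or over the unsubstituted phenyl group (no change at the digits printed from compound 3 to compound 4 (within the scatter)). A chlorine on this ring, alongside a fluorine, therefore does not reproduce the response of 4-bromophenyl (a number 83 percentage points lower from compound 2 to compound 4 (beyond the scatter)), so a halogen heavier than fluorine is not enough in itself in compound 4. No evidence at hand explains this result.

From the compounds shown here alone, it remains open whether 4-chlorophenyl, without the fluoro, would read like 4-bromophenyl or like 4-fluorophenyl, and how 4-iodophenyl or 4-methoxyphenyl would read.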